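Chloro for Trifluoromethyl in Two Related Cores

A few compounds are considered here, and "the series" means these few. Any claim that something is new, unique, unknown or untested is made for them only; others in the source may bear on it.

Measured so far:
Compound 1 `COc1cc(O)c(CC=C(C)C)c(O)c1C(=O)/C=C/c1ccc(Cl)cc1`: 11800 nM
Compound 2 `COc1cc(O)c(CC=C(C)C)c(O)c1C(=O)/C=C/c1ccc(C(F)(F)F)cc1`: 11100 nM
Compound 3 `COc1cc(OC)c(C(=O)/C=C/c2ccc(C(F)(F)F)cc2)c(OC)c1`: 14200 nM

Compound 2 and compound 1 share one core and differ only by chloro in place of trifluoromethyl on an aromatic carbon. In a functional assay on A549 cells (Homo sapiens) for inhibition, read by MTT assay, with a stated time of 72 h (a higher number here means a weaker inhibitor, a lower number a stronger inhibitor), compound 2 gives 11100 nM, and the step of a 1.1-fold higher number from compound 2 to compound 1 (0.03 log units; within the scatter) shows that this swap leaves the read-out essentially unchanged. Compound 3 carries a different core; the difference between the two cores is not broken down here. In this assay compound 3 gives 14200 nM, a number that lies within the scatter of both compound 1 and compound 2, so no order among the three can be claimed.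

Compound 4 `COc1cc(OC)c(C(=O)/C=C/c2ccc(Cl)cc2)c(OC)c1` has not yet been measured. It differs from compound 3 by chloro in place of trifluoromethyl on an aromatic carbon. The two place lines agree word for word, so this is the same change already seen between compound 2 and compound 1. The expected step of a 1.1-fold higher number from compound 3 to compound 4 (0.02 log units; within the scatter) is small because a 1.1-fold higher number from compound 2 to compound 1 (0.03 log units; within the scatter) was within the scatter. On that basis compound 4 is expected to give about 15000 nM, with a likely range from 7500 nM to 30000 nM.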

Compound 4, half-maximal inhibitory concentration: 13300 nM
Compound 4: middle estimate off by 1.1-fold (0.05 log units), on the high side, within the range that was stated.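

In this assay, among these compounds, chloro in place of trifluoromethyl on an aromatic carbon gives a 1.1-fold lower number from compound 3 to compound 4 (0.03 log units; within the scatter), so on the core of compound 3, as on the core of compound 1, the swap produces no step that can be told from the scatter. The two steps also cannot be told apart, and in that limited sense the result carries from one core to the other: the same change on two cores in this assay, a 1.1-fold higher number (0.03 log units; within the scatter) from compound 2 to compound 1 and a 1.1-fold lower number (0.03 log units; within the scatter) from compound 3 to compound 4, 1.1-fold (0.05 log units) apart, within the scatter of two such steps. This does not show that a measurable effect transfers between cores, since neither step rises above the scatter, and two cores say nothing about how the swap would behave on any other core.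

The compounds shown leave open whether a different group at this place, such as an amine, a carboxylic acid or a nitrile, would give a step beyond the scatter. Also open, on these data alone, is whether the swap stays this small in cells other than those used here.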